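Ring-opening of the amine side chain in the coumarin ether series

A few compounds are considered here, and "the series" means these few. Any claim that something is new, unique, unknown or untested is made for them only; others in the source may bear on it.

Three compounds of this series have been run in a functional assay on HUVEC cells (Homo sapiens) for inhibition, read by MTT assay, with a stated time of 24 h, tested at 10 uM; on this read-out higher numbers stand for more inhibition of growth at the one concentration tested and lower numbers for less inhibition of growth. Compound 1 `COc1cc2ccc(=O)oc2cc1OCC(O)CN1CCCC1` gives 0.5%. Compound 2 `COc1cc2ccc(=O)oc2cc1OCC(=O)c1ccc([N+](=O)[O-])cc1` gives 4.1% and compound 3 `COc1cc2ccc(=O)oc2cc1OCC(=O)c1ccccc1` gives 3.4%; all three values sit within the scatter of one another, so compound 1 is not separated from either. Within the data shown here, the only single-point step, a number 0.7 percentage points lower from compound 2 to compound 3 (within the scatter), concerns an aromatic substituent far from the amine and is itself within the scatter. Compound 4 `CCN(CC)CC(O)COc1cc2oc(=O)ccc2cc1OC` differs from compound 1 by diethylamino in place of pyrrolidin-1-yl on a saturated chain carbon, two bonds along the chain from an oxygen on a saturated carbon. Among the measured compounds shown here, no measured step touches this amine, so no movement beyond the scatter is expected; the expected step is a number 1.5 percentage points higher from compound 1 to compound 4 (within the scatter). Compound 4 is therefore estimated at 2%, with a range from -8% to 12%.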

Compound 4, percent growth inhibition at one concentration: 0.5%
Estimate against measurement, compound 4: 1.5 percentage points above; the range from low to high includes it.
By their numbers in this assay, from the lowest: compounds 1, 4, 3 and 2 (each within the scatter of the next).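

Diethylamino in place of pyrrolidin-1-yl, on a saturated chain carbon, two bonds along the chain from an oxygen on a saturated carbon, reads as no change at the digits printed from compound 1 to compound 4 (within the scatter) and is the only measured step at this amine. Ring and open chain at this place are thus not separated in this assay at the one concentration tested. No evidence at hand bears on this result.

On these data alone, whether any amine at this place can move the number remains open. Morpholin-4-yl, or a longer chain carrying the diethylamino group, would test that.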